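Trading a Urea for a Sulfonamide on the Shared Core

The compounds below may be only part of what the source reports. "The series", "measured", "known", "first", "only" and "open" are said of these compounds alone.

Compound 3 `CCCCc1ccc(CNC(=O)NC2CCCCC2)c(=O)n1Cc1ccc(-c2ccccc2-c2nn[nH]n2)cc1` is the weakest of the three measured analogues: in a functional assay (aorta) for antagonist activity, with Oryctolagus cuniculus as the target (on this read-out higher numbers stand for weaker inhibition and lower numbers for stronger inhibition), compound 3 gives 90 nM, the highest of the three numbers. Compound 1 `CCCCc1ccc(CNC(C)=O)c(=O)n1Cc1ccc(-c2ccccc2-c2nn[nH]n2)cc1` gives 3 nM, and compound 2 `CCCCc1ccc(CN(Cc2ccccc2)S(C)(=O)=O)c(=O)n1Cc1ccc(-c2ccccc2-c2nn[nH]n2)cc1` gives 2 nM. The two steps leading to compound 3 are both large, a 30-fold higher number from compound 1 to compound 3 (1.48 log units; beyond the scatter) and a 45-fold higher number from compound 2 to compound 3 (1.65 log units; beyond the scatter), whereas the step between the other two is small, a 1.5-fold lower number from compound 1 to compound 2 (0.18 log units; within the scatter).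

Compound 4 `CCCCc1ccc(CN(C(C)C)S(C)(=O)=O)c(=O)n1Cc1ccc(-c2ccccc2-c2nn[nH]n2)cc1` differs from compound 3 in one place: isopropyl(methylsulfonyl)amino in place of (cyclohexylcarbamoyl)amino on a saturated chain carbon bound to an aromatic carbon. The step from compound 2 to compound 3 bears most directly on this change, since it runs the same exchange in the opposite direction with a benzyl rather than an isopropyl group on the nitrogen, and it was large. The small step from compound 1 to compound 2 shows that the two groups on that saturated chain carbon, acetamido and benzyl(methylsulfonyl)amino, gave numbers within the scatter of one another, so the exact group on the sulfonamide nitrogen is not expected to matter greatly. Compound 4 is therefore expected to show a large downward step, a 23-fold lower number from compound 3 to compound 4 (1.35 log units; beyond the scatter). The estimate for compound 4 is 4 nM, with a range from 1.5 nM to 15 nM.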

Compound 4, half-maximal inhibitory concentration: 0.9 nM
Compound 4: the middle estimate sits 4.4-fold (0.65 log units) above what was measured, outside the stated range (below it).
By their numbers in this assay, from the lowest: compound 4; then compounds 2 and 1 (each within the scatter of the next); then compound 3.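

In this assay, the exchange of (cyclohexylcarbamoyl)amino for isopropyl(methylsulfonyl)amino on a saturated chain carbon bound to an aromatic carbon gives a 100-fold lower number from compound 3 to compound 4 (2.00 log units; beyond the scatter), so the large gap between the urea and the sulfonamide seen with a benzyl group also holds with an isopropyl group on the sulfonamide nitrogen. Among the compounds shown here, the result also offers the first direct reading of that nitrogen substituent: isopropyl in place of benzyl gives a 2.2-fold lower number from compound 2 to compound 4 (0.35 log units; beyond the scatter), a modest step but one beyond the scatter. The sulfonamide of compound 4 also separates from the acetamido group, with a 3.3-fold lower number from compound 1 to compound 4 (0.52 log units; beyond the scatter), whereas the benzyl sulfonamide stayed within the scatter of acetamido, with a 1.5-fold lower number from compound 1 to compound 2 (0.18 log units; within the scatter), so the choice of nitrogen substituent decides whether a sulfonamide stands apart from acetamido here.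

Nothing available explains why these groups give different numbers in this assay. From the compounds shown here alone, it remains open whether an ethyl or cyclopropyl group or a bare hydrogen on the sulfonamide nitrogen would continue this trend, whether phenylsulfonyl could replace methylsulfonyl, and whether a methylurea would close the gap left by the cyclohexyl urea.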